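A few compounds are considered here, and "the series" means these few. Any claim that something is new, unique, unknown or untested is made for them only; others in the source may bear on it.

Of the compounds shown here, two have been measured in a functional assay on MCF7 cells (Homo sapiens) for inhibition, read by resazurin assay, with a stated time of 72 h; a higher number here means a weaker inhibitor, a lower number a stronger inhibitor. Compound 1 `CCSc1ccc(C2C(O)C(=O)N2c2cc(OC)c(OC)c(OC)c2)cc1` gives 6 nM, while compound 2 `COc1cc(N2C(=O)C(C3CC3)C2c2ccc(SC)cc2)cc(OC)c1OC` gives 131 nM, the higher of the two numbers and so the weaker inhibitor, with a gap beyond the usual scatter. Compound 3 `CCSc1ccc(C2C(C3CC3)C(=O)N2c2cc(OC)c(OC)c(OC)c2)cc1` has not yet been measured. It departs from compound 2 in one place: methyl in place of hydrogen on a saturated chain carbon bound to a sulfur, which turns methylsulfanyl into ethylsulfanyl. The ethylsulfanyl group is also carried by compound 1, but that compound differs from compound 2 elsewhere too, so compound 1 at 6 nM does not gauge this step alone. No step beyond the scatter is therefore expected in this assay. The expected change is a 1.2-fold lower number from compound 2 to compound 3 (0.08 log units; within the scatter). Compound 3 is estimated at 110 nM, with an expected range from 35 nM to 350 nM.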

Compound 3, half-maximal inhibitory concentration: 606 nM
Compound 3: middle estimate off by 5.5-fold (0.74 log units), on the low side; measured number above the stated range.
By their numbers in this assay, from the lowest: compound 1; then compound 2; then compound 3.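

In this assay, the change from methylsulfanyl to ethylsulfanyl is not neutral when cyclopropyl is present, since the added methyl on a saturated chain carbon bound to a sulfur gives a weaker inhibitor (step: a 4.6-fold higher number from compound 2 to compound 3 (0.67 log units; beyond the scatter)). With ethylsulfanyl held constant, the saturated ring carbon also proves highly sensitive, as cyclopropyl in place of hydroxy gives a large loss of inhibition (step: a 100-fold higher number from compound 1 to compound 3 (2.00 log units; beyond the scatter)). Nothing available explains either step.

The compounds shown leave open whether the methylsulfanyl to ethylsulfanyl step would read the same with hydroxy, rather than cyclopropyl, on the saturated ring carbon. They also leave open how a longer chain such as propylsulfanyl, or an amine on that ring carbon, would behave.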